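Nitro to Difluoro Exchange on a Shared Acylurea Core

This account rests on a few compounds, and the source may have more. Where it says the series, first, only, none or still open, it means among the compounds named here.

Going by the values given here, compound 1 `CN(C(=O)NC(=O)c1ccc([N+](=O)[O-])cc1)c1nc(C(F)(F)F)c(C(=O)N/N=C/c2ccc([N+](=O)[O-])cc2)s1` gives the only number in a functional assay on MCF7 cells (Homo sapiens) for inhibition, read by MTT assay, with a stated time of 72 h; on this read-out lower numbers stand for stronger inhibition and higher numbers for weaker inhibition: compound 1 gives 9.24 ug/mL. The other value shown sits at the limit of > 100 ug/mL in this assay, at which 1 of the 2 values shown sits. Compound 2 `CNc1nc(C(F)(F)F)c(C(=O)N/N=C/c2cccc(C(F)(F)F)c2)s1` reaches only a limit in this assay, > 100 ug/mL. Compound 3 `CN(C(=O)NC(=O)c1ccc(F)c(F)c1)c1nc(C(F)(F)F)c(C(=O)N/N=C/c2ccc([N+](=O)[O-])cc2)s1` differs from compound 1 by 3,4-difluorophenyl in place of 4-nitrophenyl on a carbonyl carbon. Among the compounds with values here, no measured pair shows this kind of change, so the step from compound 1 to compound 3 is expected to be small, a 1.6-fold higher number from compound 1 to compound 3 (0.21 log units; within the scatter), likely within the scatter or slightly weaker. Compound 3 is therefore estimated at 15 ug/mL, with a range from 5 ug/mL to 50 ug/mL.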

Compound 3, half-maximal inhibitory concentration: 4.81 ug/mL
Beside the measured number, compound 3's estimate is 3.1-fold (0.49 log units) above it; the measured number lies below the stated range.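

On the shared core, 3,4-difluorophenyl in place of 4-nitrophenyl on a carbonyl carbon gives a 1.9-fold lower number from compound 1 to compound 3 (0.28 log units; within the scatter) in this assay. The position therefore tolerates this exchange, and compound 3 shows that a measurable number here does not depend on the nitro group of this ring. Nothing shown explains this outcome.

From the compounds shown here alone, it remains open whether a smaller group such as methyl, or a carboxylic acid or an amine on this phenyl ring, would hold the number. Going by these compounds, the second 4-nitrophenyl, shared by compound 1 and compound 3, also remains open.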